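This account rests on a few compounds, and the source may have more. Where it says the series, first, only, none or still open, it means among the compounds named here.

Two compounds of the series have numbers in a physicochemical assay, read by spectrophotometry, with a stated time of 10 min, tested at 0.5 mM, in the presence of a further agent that is not named here; a higher number here means a stronger effect of the compound at the concentration tested, a lower number a weaker effect. Compound 1, `COc1cc(/C=C/C(=O)NCCCCC(N)CN)ccc1O`, gives 42.9% in this assay. Compound 2, `NCC(N)CC(=O)N1CCN(C(=O)CCn2cccc(O)c2=O)CC1`, gives 68.5% in this assay. Among the measured compounds shown here, on these two numbers compound 2 stands highest; its only neighbour is compound 1, whose value lies lower by a margin beyond the usual scatter of repeated measurements. For the measured compounds named here, no pair of measured compounds differs in one place only, so no single-change step can be read from.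

Compound 3, `NCC(N)CCC(=O)N1CCN(C(=O)CCn2cccc(O)c2=O)CC1`, is not yet measured in this assay. Against compound 2 it differs in one place: 2,3-diaminopropyl in place of 1,2-diaminoethyl on a saturated chain carbon bound to a carbonyl carbon. The numbers of hydrogen-bond donors and acceptors are unchanged by this. Nothing measured in the series shows what this change does in this assay, so the expectation rests on the value of compound 2 alone. The expected step in this assay is a number 3.5 percentage points lower from compound 2 to compound 3 (within the scatter), taken to lie within the scatter. Compound 3 is accordingly estimated at 65% in this assay, with a range from 50% to 78%.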

Compound 3, a percentage reported as activity, at one concentration (the size of the read-out at that concentration, not a potency): 71.6%
Compound 3: the middle estimate sits 6.6 percentage points below what was measured; low and high end bracket the measured number.
By their numbers in this assay, from the lowest: compound 1; then compounds 2 and 3 (each within the scatter of the next).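

Working notes on the series: in this assay, putting 2,3-diaminopropyl in place of 1,2-diaminoethyl on a saturated chain carbon bound to a carbonyl carbon gives a number 3.1 percentage points higher from compound 2 to compound 3 (within the scatter) as the first single-change step that can be read within the series. This place therefore accepts either of these two diaminoalkyl groups, with no read-out difference that can be separated from the usual scatter, and the two groups have the same counts of hydrogen-bond donors and acceptors. No supporting observation is available to explain why the two values fall within the scatter of each other.

This rests on a single step at a single concentration, so it does not show how far the tolerance at this place extends to a longer chain carrying the two amines, to a single primary amine, or to a carboxylic acid in place of the diaminoalkyl group. Among the compounds shown here, also open is whether the same replacement would give a similar step on the core of compound 1 , where no single-change pair can yet be read.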